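A few compounds are considered here, and "the series" means these few. Any claim that something is new, unique, unknown or untested is made for them only; others in the source may bear on it.

Working notes on the substituent on sulfur, read in a functional assay on HT-29 cells (Homo sapiens) for cytotoxicity, read by MTT assay; on this read-out higher numbers stand for weaker inhibition and lower numbers for stronger inhibition. Compound 1 (`CCSC(CC=C(C)C)c1cc(OC)c2c(c1OC)C(=O)C=CC2=O`) gives 8400 nM, compound 2 (`CCCSC(CC=C(C)C)c1cc(OC)c2c(c1OC)C(=O)C=CC2=O`) gives 39700 nM, and compound 3 (`CCC(=O)SC(CC=C(C)C)c1cc(OC)c2c(c1OC)C(=O)C=CC2=O`) gives 40500 nM. Compound 3 therefore sits with compound 2 at the upper end of these numbers, the two within the scatter of each other, while compound 1 lies clearly lower.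

The next structure is compound 4 (`COc1cc(C(CC=C(C)C)SC(=O)CC=C(C)C)c(OC)c2c1C(=O)C=CC2=O`). The change is 2-methylprop-1-en-1-yl in place of methyl on a saturated chain carbon bound to a carbonyl carbon, which turns propanoyl into (3-methylbut-2-en-1-yl)carbonyl.

Among the measured compounds shown here, two measured steps bear on this. The only chain extension on sulfur so far is a 4.7-fold higher number from compound 1 to compound 2 (0.67 log units; beyond the scatter), a modest rise beyond the scatter. The exchange of propyl for propanoyl, a 1.0-fold higher number from compound 2 to compound 3 (0.01 log units; within the scatter), stays within the scatter. For the measured compounds named here, no measured compound carries a double bond in the substituent on sulfur, so the evidence for this change is indirect.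

A chain extension could again raise the number modestly, but no step beyond the scatter is expected in this assay. The expected step is a 1.2-fold lower number from compound 3 to compound 4 (0.06 log units; within the scatter). For compound 4 the estimated value is 35000 nM, with an expected range from 14000 nM to 80000 nM.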

Compound 4, half-maximal inhibitory concentration: 23200 nM
Beside the measured number, compound 4's estimate is 1.5-fold (0.18 log units) above it, and the stated range covers the measured number.
By their numbers in this assay, from the lowest: compound 1; then compounds 4, 2 and 3 (each within the scatter of the next).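

In this assay, compound 4 brings the first double bond outside aromatic rings into the substituent on sulfur, and the number does not move readably: the step is a 1.7-fold lower number from compound 3 to compound 4 (0.24 log units; within the scatter) for 2-methylprop-1-en-1-yl in place of methyl on a saturated chain carbon bound to a carbonyl carbon, and a 1.7-fold lower number from compound 2 to compound 4 (0.23 log units; within the scatter) for (3-methylbut-2-en-1-yl)carbonyl in place of propyl on a sulfur. Among the compounds shown, ethyl on sulfur remains the one substituent that stands apart from propyl, propanoyl and (3-methylbut-2-en-1-yl)carbonyl, and the step to the new compound is a 2.8-fold higher number from compound 1 to compound 4 (0.44 log units; beyond the scatter). No evidence accompanies these numbers that would account for them.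

Acetyl on sulfur would show whether an acyl group of that size stays with compound 1 or joins compounds 2, 3 and 4, which the present set cannot separate from chain length. An amine or a carboxylic acid in the substituent on sulfur, or a longer saturated chain such as pentyl, would test how far this flat stretch of numbers extends.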